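This account rests on a few compounds, and the source may have more. Where it says the series, first, only, none or still open, it means among the compounds named here.

Of the compounds shown here, two have been measured in a functional assay on NCI-H522 cells (Homo sapiens) for cytotoxicity, with a stated time of 3 days; on this read-out higher numbers stand for weaker inhibition and lower numbers for stronger inhibition. Compound 1 `Ic1nc2ccccc2o1` gives 11700 nM in this assay, the only number shown in the set so far. Compound 2 `C#CCNC(=O)c1csc(Br)n1` reaches only > 40000 nM in this assay, which is a limit of the assay rather than a number (the limit of > 40000 nM in this assay, at which 1 of the 2 values shown sits). Going by the values given here, no two measured compounds differ in a single place, so no measured step is available. The compound not yet measured is compound 3 `C=Cc1nc2ccccc2o1`, which differs from compound 1 by vinyl in place of iodo on an aromatic carbon. Among the compounds with values here, with no measured step to lean on, the change from compound 1 to compound 3 is expected to move the value only modestly, likely not beyond the scatter of this assay, in either direction. For compound 3 the estimate in this assay is 12000 nM, with a range from 4000 nM to 40000 nM, an expected step of a 1.0-fold higher number from compound 1 to compound 3 (0.01 log units; within the scatter).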

Compound 3, half-maximal inhibitory concentration: > 40000 nM
Compound 3: only a limit was reported; the forecaster's own chance of this, stated with the estimate: 20%; at least 3.3-fold (0.52 log units) between middle value and limit.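

The series now has its first measured step at this position, on an aromatic carbon next to the ring nitrogen and next to the ring oxygen: an at least 3.4-fold higher number from compound 1 to compound 3 (0.53 log units; beyond the scatter). Compound 3 gives > 40000 nM in this assay, which is a limit of the assay and not a number. The change from iodo to vinyl is therefore not neutral on this read-out, and its full size cannot be read, as the step ends at the limit: the limit of > 40000 nM in this assay, at which 2 of the 3 values shown sit.

The compounds shown leave open whether the measurable value of compound 1 depends on iodo itself, or whether another group at this place, such as chloro, an amine or an ethyl chain, would also give a number. As far as these compounds go, how far compound 3 lies past its limit also stays open.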